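The compounds below may be only part of what the source reports. "The series", "measured", "known", "first", "only" and "open" are said of these compounds alone.

Compound 1 `CS(=O)(=O)Nc1ccc(-n2cc(-c3ccccc3)nn2)cc1Oc1ccccc1` and compound 2 `Cc1ccc(OCc2cn(-c3ccc(NS(C)(=O)=O)c(Oc4ccccc4)c3)nn2)cc1` share one core and differ in a single place. In a functional assay on HeLa cells (Homo sapiens) for inhibition, read by MTT assay, with a stated time of 48 h (a higher number here means a weaker inhibitor, a lower number a stronger inhibitor), compound 1 gives 21900 nM, while compound 2 gives 15800 nM. For the measured compounds named here, the step of a 1.4-fold lower number from compound 1 to compound 2 (0.14 log units; within the scatter) lies within the scatter, so compound 2 stands alongside compound 1 on the only two numbers that exist. A third member of the series, compound 3 `CS(=O)(=O)Nc1ccc(-n2cc(OCc3ccccc3)nn2)cc1Oc1ccccc1`, has in this assay only the entry "not determined" (no result reported), so no number exists for compound 3. Compound 4 `CS(=O)(=O)Nc1ccc(-n2cc(COc3ccc4ccccc4c3)nn2)cc1Oc1ccccc1` has not been measured; it differs from compound 2 by naphthalen-2-yl in place of 4-methylphenyl on an oxygen on a saturated carbon. Going by the values given here, only one measured step bears on this change, and it stayed within the scatter when a group on the same arm of the core was exchanged. Among the compounds with values here, nothing among the measured compounds indicates that exchanging 4-methylphenyl for naphthalen-2-yl on this oxygen would move the number beyond the scatter. Compound 4 is therefore expected to give a number close to that of compound 2. The step of a 1.3-fold lower number from compound 2 to compound 4 (0.12 log units; within the scatter) is expected to remain within the scatter. The estimate for compound 4 in this assay is 12000 nM, lying between 5000 nM and 30000 nM.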

Compound 4, half-maximal inhibitory concentration: 12800 nM
Compound 4: middle estimate off by 1.1-fold (0.03 log units), on the low side; low and high end bracket the measured number.
By their numbers in this assay, from the lowest: compounds 4, 2 and 1 (each within the scatter of the next).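

Compound 1 to compound 2 had replaced the whole arm on the aromatic carbon, whereas this change touches only the aryl group on the oxygen. In this assay exchanging 4-methylphenyl for naphthalen-2-yl gives a 1.2-fold lower number from compound 2 to compound 4 (0.09 log units; within the scatter) and so shows that this oxygen can carry a second six-membered aromatic ring, 10 heavy atoms in place of 7, with the number staying within the scatter. No measurement here accounts for this result.

As far as these compounds go, every group on this oxygen with a number is made of carbon alone, so it remains open whether a pyridine ring, or a phenyl ring bearing an amine or a carboxylic acid, would move the number beyond the scatter. Compound 3 has no number, so its shorter link between the triazole-bearing arm and the phenyl ring cannot be judged.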